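The source may hold more compounds than are shown below. What is called first, only, known or untested is meant among the compounds shown, and "the series" means these compounds.

Compound 1 `C/C=C/C(=O)N1CCCC(n2nc(-c3ccc(Oc4ccccc4)cc3)cc2C(=O)OCC)C1` is the weakest point on the numbers at hand: in a functional assay on JeKo-1 cells (Homo sapiens) for inhibition, read by luminescence and CellTiter-Glo, with a stated time of 72 h (a lower number here means a stronger inhibitor, a higher number a weaker inhibitor), compound 1 gives 26500 nM, the highest of the three values measured. Its closest neighbour is compound 2 `C=CC(=O)N1CCCC(n2nc(-c3ccc(Oc4ccccc4)cc3)cc2C(=O)OCC)C1`, which in this assay gives 21200 nM; the step of a 1.3-fold lower number from compound 1 to compound 2 (0.10 log units; within the scatter) shows that swapping the acryl-type group has no effect beyond the scatter. Going by the values given here, the third compound, compound 3 `O=C(CCl)Nc1ccc(Cn2nc(-c3ccc(Oc4ccccc4)cc3)cc2C(=O)O)cc1`, gives 2500 nM in this assay, a lower value than that of compound 1, but it differs from compound 1 in several places at once and no single step connects the two.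

Compound 4 `C/C=C/C(=O)N1CCCC(n2nc(-c3ccc(Oc4ccccc4)cc3)cc2C(=O)O)C1` keeps everything of compound 1 except one change: hydrogen in place of ethyl on an oxygen next to a carbonyl group. Among the compounds with values here, none of the measured steps addresses this change; the only step at hand, from compound 1 to compound 2, concerns a different part of the molecule and is within the scatter. Compound 3 also carries the carboxy group and shows the lowest value, which hints that a lower number could follow, but its other differences leave this unresolved. A moderate drop is therefore expected, a 2.2-fold lower number from compound 1 to compound 4 (0.34 log units; beyond the scatter), with wide uncertainty. For compound 4 the estimate in this assay is 12000 nM, expected to lie between 4000 nM and 40000 nM.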

Compound 4, half-maximal inhibitory concentration: > 60000 nM
Compound 4: a limit, no number; the forecaster's own chance of this, stated with the estimate: 10%; middle value at least 5.0-fold (0.69 log units) from the limit.
By their numbers in this assay, from the lowest: compound 3; then compounds 2 and 1 (each within the scatter of the next). At a limit, above all of these: compound 4.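

For compound 4 the result in this assay is a limit and not a number: the limit of > 60000 nM in this assay, at which 1 of the 4 values shown sits. Going by these compounds alone, the change from ethoxycarbonyl to carboxy gives an at least 2.2-fold higher number from compound 1 to compound 4 (0.35 log units; beyond the scatter), so this site on the shared core responds to a change beyond the scatter, whereas the only earlier single-place step, a 1.3-fold lower number from compound 1 to compound 2 (0.10 log units; within the scatter), concerned a different part of the molecule and stayed within the scatter. Compound 3 also carries a carboxy group and gives 2500 nM, but it differs from compound 4 in several places, so the effect of the carboxy group cannot be read from that pair.

The compounds shown leave open how other groups would behave at this site, such as methoxycarbonyl, a primary carboxamide or an ester with a longer chain, and so whether the number follows the ethyl group specifically or the ester as a whole. Also open, going by these compounds, is whether hydrogen in place of ethyl has the same effect on the core of compound 2, which carries vinyl in place of prop-1-en-1-yl on the carbonyl carbon.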